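One Double Bond Redrawn, Same Atoms

A few compounds are considered here, and "the series" means these few. Any claim that something is new, unique, unknown or untested is made for them only; others in the source may bear on it.

In a functional assay on HL-60 cells (Homo sapiens) for cytotoxicity (a lower number here means a stronger inhibitor, a higher number a weaker inhibitor), compound 1 (`CC1(C)CCC(C)(C)c2cc(/C=C/c3cccc(N)c3)ccc21`) gives 20000 nM and compound 2 (`COc1ccc(/C=C\c2ccc3c(c2)C(C)(C)CCC3(C)C)cc1N`) gives 25000 nM and these two numbers lie within the scatter of each other. Compound 3 (`COc1ccc(/C=C/c2ccc3c(c2)C(C)(C)CCC3(C)C)cc1N`) has not been measured yet. It keeps the atoms and bonds of compound 2 and changes only the drawn shape of its double bond, from Z to E (the two compounds have the same atoms and bonds and differ only in configuration as drawn: 1 of 1 stereo elements differ; a double bond is drawn Z in compound 2 and E in compound 3). For the measured compounds named here, no measured pair shows what such a switch does, so the data favour no direction. The a 1.3-fold lower number from compound 2 to compound 3 (0.10 log units; within the scatter) is expected to stay within the scatter. Compound 3 is estimated at 20000 nM (expected range 7000 nM to 50000 nM).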

Compound 3, half-maximal inhibitory concentration: 61000 nM
Beside the measured number, compound 3's estimate is 3.1-fold (0.48 log units) below it, and the stated range ends below it.
By their numbers in this assay, from the lowest: compounds 1 and 2 (each within the scatter of the next); then compound 3.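

In this assay, the drawn shape of the double bond matters on its own, with the switch giving a 2.4-fold higher number from compound 2 to compound 3 (0.39 log units; beyond the scatter). That shift belongs to the double bond alone because nothing else separates the pair: the fact that compounds 2 and 3 differ only in the configuration as drawn. With the E double bond kept, methoxy in place of hydrogen on an aromatic carbon gives a 3.1-fold higher number from compound 1 to compound 3 (0.48 log units; beyond the scatter), a weaker result. What these compounds leave open is whether the Z shape would keep its advantage without the methoxy, and whether a hydroxyl or an ethoxy group in its place would change the number.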